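Halogen pattern on the benzyl group: step to compound 3

The compounds below may be only part of what the source reports. "The series", "measured", "known", "first", "only" and "open" are said of these compounds alone.

In a functional assay on CCRF-CEM cells (Homo sapiens) for antiproliferative activity, with a stated time of 72 h (on this read-out higher numbers stand for weaker inhibition and lower numbers for stronger inhibition), compound 2 `OC[C@H]1O[C@@H](n2cnc3c(NCc4ccccc4Br)ncnc32)[C@H](O)[C@@H]1O` stands highest at 12300 nM, against compound 1 `OC[C@H]1O[C@@H](n2cnc3c(NCc4ccc(F)cc4)ncnc32)[C@H](O)[C@@H]1O` at 1250 nM. Compound 3 `OC[C@H]1O[C@@H](n2cnc3c(NCc4ccc(Cl)cc4Cl)ncnc32)[C@H](O)[C@@H]1O` brings (2,4-dichlorophenyl in place of 2-bromophenyl on a saturated chain carbon bound to a nitrogen on an aromatic ring), with 2,4-dichlorophenyl in place of 2-bromophenyl on a saturated chain carbon bound to a nitrogen on an aromatic ring. Among the compounds with values here, the only measured step bearing on this is a 9.8-fold higher number from compound 1 to compound 2 (0.99 log units; beyond the scatter), with 2-bromophenyl in place of 4-fluorophenyl at that place. The new group's name carries both numbered positions, so a partial return toward compound 1 is expected, smaller than that step. The expected change is a 2.5-fold lower number from compound 2 to compound 3 (0.39 log units; beyond the scatter). Compound 3 is estimated at 5000 nM, within 1500 nM to 15000 nM.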

Compound 3, half-maximal inhibitory concentration: 86700 nM
Estimate against measurement, compound 3: 17-fold (1.24 log units) below, outside the stated range (above it).
By their numbers in this assay, from the lowest: compound 1; then compound 2; then compound 3.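

In this assay the 2,4-dichlorophenyl group on a saturated chain carbon bound to a nitrogen on an aromatic ring brings no return toward the 4-fluorophenyl number: the series shows a 7.0-fold higher number from compound 2 to compound 3 (0.85 log units; beyond the scatter) and a 69-fold higher number from compound 1 to compound 3 (1.84 log units; beyond the scatter) overall. Among these three compounds, both replacements of 4-fluorophenyl give higher numbers, and no compound goes against this. Nothing available explains the rise.

Halogen identity and halogen count change together in the step to 2,4-dichlorophenyl, so their contributions remain unseparated. The 2-chlorophenyl and 4-chlorophenyl groups would divide that step into single changes.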